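A few compounds are considered here, and "the series" means these few. Any claim that something is new, unique, unknown or untested is made for them only; others in the source may bear on it.

For the measured compounds named here, in a functional assay on DLD-1 cells (Homo sapiens) for cytotoxicity, with a stated time of 48 h (on this read-out lower numbers stand for stronger inhibition and higher numbers for weaker inhibition), compound 1 `COc1ccc2oc(/C=C/[S+](C)[O-])cc(=O)c2c1` gives 5700 nM and compound 2 `C[S+]([O-])/C=C/c1cc(=O)c2cc(OC(=O)C(C)(C)C)ccc2o1` gives 8000 nM, so compound 2 stands within the scatter of the only other measured value. Compound 3 `C[S+]([O-])/C=C/c1cc(=O)c2cc(Br)ccc2o1` carries bromo in place of ((tert-butyl)carbonyl)oxy on an aromatic carbon. Going by the values given here, the only measured step bearing on this is a 1.4-fold higher number from compound 1 to compound 2 (0.15 log units; within the scatter), which is small, but it does not test bromo. No step beyond the scatter is therefore expected in this assay. The expected step is a 1.3-fold lower number from compound 2 to compound 3 (0.12 log units; within the scatter). For compound 3 the estimated value is 6000 nM, with a range of 2500 nM to 15000 nM.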

Compound 3, half-maximal inhibitory concentration: 4500 nM
Beside the measured number, compound 3's estimate is 1.3-fold (0.12 log units) above it, and the stated range covers the measured number.
By their numbers in this assay, from the lowest: compounds 3, 1 and 2 (each within the scatter of the next).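

In this assay, bromo in place of ((tert-butyl)carbonyl)oxy gives a 1.8-fold lower number from compound 2 to compound 3 (0.25 log units; within the scatter), and bromo in place of methoxy gives a 1.3-fold lower number from compound 1 to compound 3 (0.10 log units; within the scatter). For the compounds shown here, this position therefore shows no step beyond the scatter even with a single bromine atom, which has no oxygen and no hydrogen-bond acceptors, whereas the earlier compounds compared only oxygen-linked groups. No evidence available here explains these numbers.

Going by these compounds, whether an amine or a carboxylic acid on this aromatic carbon would move the number beyond the scatter remains open. On these data alone, the effect of changes elsewhere on the shared core also remains open.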